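This account rests on a few compounds, and the source may have more. Where it says the series, first, only, none or still open, it means among the compounds named here.

Working notes on the series. One core runs through compound 1 `CN1CC[C@H]2CCC[C@@H](NC(=O)c3ccc(Cl)cc3)[C@@H]2C1`, compound 2 `CN1CC[C@H]2CCC[C@@H](OC(=O)c3ccc(Cl)cc3)[C@@H]2C1` and compound 3 `COc1cc(C(=O)N[C@@H]2CCC[C@@H]3CCN(C)C[C@@H]32)cc(OC)c1OC`. In a physicochemical assay for acid dissociation, compound 1 gives 8.83. Compound 2 gives 8.75 in this assay, and compound 3 gives 9.02 in this assay. Of the three numbers shown, compound 1 stands second highest; it differs from compound 2 by an amount within the scatter and from compound 3 by an amount that is also within the scatter. Among the measured compounds shown here, no two of these three compounds differ in one place only, so no single step between measured compounds can be read from them.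

Compound 4 `CN1CC[C@H]2CCC[C@@H](NC(=O)c3ccccc3)[C@@H]2C1` is not yet measured. It differs from compound 1 by hydrogen in place of chloro on an aromatic carbon, on an aromatic carbon of a six-membered aromatic ring of carbon only, para to a large group; cut one bond further out, the change reads 4-chlorophenyl to phenyl. The three measured values sit within the scatter of one another, so nothing measured here points to a step of any size for this change. The step is expected to be small, a number 0.05 log units higher from compound 1 to compound 4 (within the scatter), and not beyond the scatter. Compound 4 is expected to give 8.88 in this assay, within a range of 8.6 to 9.15.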

Compound 4, acid dissociation constant: 8.99
Estimate against measurement, compound 4: 0.11 log units below; low and high end bracket the measured number.
By their numbers in this assay, from the lowest: compounds 2, 1, 4 and 3 (each within the scatter of the next).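

Among the compounds shown here, the series now holds its first pair that differs in one place: with hydrogen in place of chloro on an aromatic carbon, para to a large group, this assay gives a number 0.16 log units higher from compound 1 to compound 4 (within the scatter) and so offers a direct reading of this change, which the earlier compounds could not supply. On the core of compound 1, this assay therefore does not separate 4-chlorophenyl from phenyl at this position, and the chloro can be absent without a step beyond the scatter. No supporting measurement bears on the reason for this result.

Whether another group at this place, such as methoxy, an amine or a carboxylic acid, would give a step beyond the scatter remains open, and the single pair shown says nothing about how the change from 4-chlorophenyl to phenyl behaves on any other core. Steps from compound 2 and compound 3 to compound 4 cannot be read, and these compounds differ from compound 4 in more than one place.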